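Trimming the Carbamate Side Chain of Compound 3

A few compounds are considered here, and "the series" means these few. Any claim that something is new, unique, unknown or untested is made for them only; others in the source may bear on it.

Three close relatives of one shared core have been measured in a functional assay (Oryctolagus cuniculus) for inhibition of platelet-activating factor receptor (Cavia porcellus); on this read-out higher numbers stand for weaker inhibition and lower numbers for stronger inhibition. Compound 1, `CCCC(=O)OCC1CN(C(=O)c2cc(OC)c(OC)c(OC)c2)CCN1C(=O)c1cc(OC)c(OC)c(OC)c1`, carries a plain propyl ester and gives 420 nM. Compound 2, `COc1cc(C(=O)N2CCN(C(=O)c3cc(OC)c(OC)c(OC)c3)C(COC(=O)NC(C)(C)C)C2)cc(OC)c1OC`, replaces that ester with a tert-butyl carbamate and gives 130 nM, a change of a 3.2-fold lower number from compound 1 to compound 2 (0.51 log units; beyond the scatter). Compound 3, `COc1cc(C(=O)N2CCN(C(=O)c3cc(OC)c(OC)c(OC)c3)C(COC(=O)NC(C)C(C)(C)C)C2)cc(OC)c1OC`, carries a 1,2,2-trimethylpropyl carbamate instead and gives 170 nM; against compound 1 this is a 2.5-fold lower number from compound 1 to compound 3 (0.39 log units; beyond the scatter), and against compound 2 it is a 1.3-fold higher number from compound 2 to compound 3 (0.12 log units; within the scatter). Compound 3 thus stands second highest of the three numbers, close to compound 2 and clearly apart from compound 1.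

Compound 4, `CCC(CC)NC(=O)OCC1CN(C(=O)c2cc(OC)c(OC)c(OC)c2)CCN1C(=O)c1cc(OC)c(OC)c(OC)c1`, takes the same core one step further: pentan-3-yl in place of 1,2,2-trimethylpropyl on an amide-type nitrogen. Among the compounds with values here, the step that bears most directly on this is the one from compound 2 to compound 3, which also swapped one branched alkyl for another on that nitrogen and stayed within the scatter, a 1.3-fold higher number from compound 2 to compound 3 (0.12 log units; within the scatter). The larger steps from compound 1 concern the change from ester to carbamate, which compound 4 keeps. A step of no change at the digits printed from compound 3 to compound 4 (within the scatter) is therefore expected, not beyond the scatter. Compound 4 is estimated at 170 nM, with a range from 80 nM to 350 nM.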

Compound 4, half-maximal inhibitory concentration: 130 nM
The estimate for compound 4 lay 1.3-fold (0.12 log units) above the measured number; measured number inside the range.
By their numbers in this assay, from the lowest: compounds 2, 4 and 3 (each within the scatter of the next); then compound 1.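

On the amide-type nitrogen of the carbamate, pentan-3-yl, with 5 heavy atoms against the 6 of 1,2,2-trimethylpropyl, now joins the other two branched alkyl groups, and in this assay the swap gives a 1.3-fold lower number from compound 3 to compound 4 (0.12 log units; within the scatter), while the comparison with tert-butyl gives no change at the digits printed from compound 2 to compound 4 (within the scatter), so this place has now accepted three different branched groups with no step beyond the scatter. The separation from the propyl ester also holds for this third carbamate, at a 3.2-fold lower number from compound 1 to compound 4 (0.51 log units; beyond the scatter), which means that all three carbamates shown lie apart from compound 1 and none goes against that pattern. No measurement is available here to explain why these three groups read alike.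

As far as these compounds go, all the groups compared on this nitrogen so far are branched alkyl groups, so it remains open whether a straight butyl chain, or a chain ending in an amine or a carboxylic acid, would fit the same pattern. From the compounds shown here alone, it is also open whether the amide hydrogen of the carbamate matters, which a methyl group on that nitrogen would begin to test.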